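The source may hold more compounds than are shown below. What is called first, only, known or untested is meant among the compounds shown, and "the series" means these compounds.

Compound 1 `CCN(CC)c1ccc2cc(C(=O)c3ccc(N4CCN(C(=O)COc5ccc(Cl)cc5Cl)CC4)cc3)oc2c1`: in a functional assay on HeLa cells (Homo sapiens) for cytotoxicity, read by MTT assay, with a stated time of 48 h (a higher number here means a weaker inhibitor, a lower number a stronger inhibitor), compound 1 gives 30 nM.
Compound 2 `CCN(CC)c1ccc2cc(C(=O)c3ccc(N4CCN(S(=O)(=O)c5ccc(Br)cc5)CC4)cc3)oc2c1`: in this assay compound 2 gives > 40000 nM, a limit of the assay rather than a number.
Compound 3 `CCN(CC)c1ccc2cc(C(=O)c3ccc(N4CCN(S(=O)(=O)c5ccc([N+](=O)[O-])cc5)CC4)cc3)oc2c1`: in this assay compound 3 gives > 40000 nM, likewise a limit.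

Compound 3 therefore stands at the limit shared with compound 2, as the limit of > 40000 nM in this assay, at which 2 of the 3 values shown sit, records, and only compound 1 has a measured number. Compound 4 `CCN(CC)c1ccc2cc(C(=O)c3ccc(N4CCN(S(=O)(=O)c5ccc(C(F)(F)F)cc5)CC4)cc3)oc2c1` differs from compound 3 by trifluoromethyl in place of nitro on an aromatic carbon. The sized steps, an at least 1300-fold higher number from compound 1 to compound 2 (3.12 log units; beyond the scatter) and an at least 1300-fold higher number from compound 1 to compound 3 (3.12 log units; beyond the scatter), both lead from the amide of compound 1 to a sulfonyl compound at the limit. The step that the two limits leave unreadable from compound 2 to compound 3, which also exchanges a group on an aromatic carbon, cannot be sized. Compound 4 keeps the sulfonyl of compound 2 and compound 3, so compound 4 is expected to remain at the limit. The step of a number no higher from compound 3 to compound 4 (the limit leaves the size open) is estimated as none beyond the scatter. Compound 4 is estimated at 40000 nM, between 15000 nM and 100000 nM.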

Compound 4, half-maximal inhibitory concentration: 9720 nM
Compound 4: middle estimate off by 4.1-fold (0.61 log units), on the high side, outside the stated range (below it).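

With the sulfonyl kept, the group on the aromatic carbon para to a large group does shift the read-out in this assay: trifluoromethyl gives an at least 4.1-fold lower number from compound 3 to compound 4 (0.61 log units; beyond the scatter) and an at least 4.1-fold lower number from compound 2 to compound 4 (0.61 log units; beyond the scatter). The sulfonyl compounds shown therefore do not all sit at a limit, and compound 4 is the only one of them with a measured number. The true size of both steps stays open, and the step between compound 2 and compound 3 cannot be read, since both rest on a limit: the limit of > 40000 nM in this assay, at which 2 of the 4 values shown sit.

Going by these compounds, how an amine, a carboxylic acid or a methoxy group would read at this place remains open. So does whether trifluoromethyl would have any such effect in the amide series of compound 1.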